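Amino for chloro on the fused ring of compound 2

This account rests on a few compounds, and the source may have more. Where it says the series, first, only, none or still open, it means among the compounds named here.

Within the data shown here, the series so far holds two measured compounds. Compound 1 `Nc1nn(C(=O)Nc2ccc(Cc3ccccc3)cc2)c2ccccc12` gives 63100 nM in a functional assay on OVCAR-3 cells (Homo sapiens) for antiproliferative activity, read by sulforhodamine B assay, with a stated time of 48 h; a higher number here means a weaker inhibitor of growth, a lower number a stronger inhibitor of growth. Compound 2 `Nc1nn(C(=O)Nc2ccc(Cc3ccccc3)cc2)c2ccc(Cl)cc12` carries a chloro on the fused ring and gives 20800 nM in this assay. Among the measured compounds shown here, the only measured step is a 3.0-fold lower number from compound 1 to compound 2 (0.48 log units; beyond the scatter), so compound 2 stands at the lowest of the two numbers, with compound 1 as its sole neighbour.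

Compound 3 `Nc1ccc2c(c1)c(N)nn2C(=O)Nc1ccc(Cc2ccccc2)cc1` is the next variation: amino in place of chloro on an aromatic carbon. For the measured compounds named here, no measured step introduces an amino anywhere, so the step from compound 1 to compound 2 is the only one that bears on the same position, and it only shows what a chloro did there, not what an amino does. Going by the values given here, with one substituent swapped for another and no precedent for the incoming group, the expectation for compound 3 is a step of a 1.9-fold higher number from compound 2 to compound 3 (0.28 log units; within the scatter) in this assay, towards a higher number and with wide uncertainty. The estimate for compound 3 in this assay is 40000 nM, with a range from 12000 nM to 130000 nM.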

Compound 3, concentration for total growth inhibition: 28300 nM
The estimate for compound 3 lay 1.4-fold (0.15 log units) above the measured number, and the stated range covers the measured number.
By their numbers in this assay, from the lowest: compounds 2 and 3 (each within the scatter of the next); then compound 1.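

In this assay the step from chloro to amino is a 1.4-fold higher number from compound 2 to compound 3 (0.13 log units; within the scatter), so this aromatic carbon does not separate the two groups, although amino carries the hydrogen-bond donor and acceptor counted for it and chloro carries none. Set against hydrogen, amino gives a 2.2-fold lower number from compound 1 to compound 3 (0.35 log units; beyond the scatter) in the same direction as the chloro step, a 3.0-fold lower number from compound 1 to compound 2 (0.48 log units; beyond the scatter), so two different groups on this carbon each lie beyond the scatter from the unsubstituted compound, both by a modest step, among these three compounds. Nothing measured on these compounds bears on why either group gives a lower number than hydrogen.

Three compounds cannot show whether any group on this carbon would give a similar step or whether the result is particular to chloro and amino, and a methoxy, a carboxylic acid or a dimethylamino group there would test this. On these data alone, it also remains open whether a substituent on another carbon of the same six-membered ring, or a change to the benzyl end of the molecule, would move the number further than the steps seen here.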